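Swapping Fluoro for Trifluoromethyl: An Expected Shift

This account rests on a few compounds, and the source may have more. Where it says the series, first, only, none or still open, it means among the compounds named here.

Compound 1 `FC(F)(F)c1ccc(C2CC(c3ccccc3)=NN2c2ccc(-c3ccccc3)nn2)cc1` is tested in a functional assay on A549 cells (Homo sapiens) for antiproliferative activity, read by MTT assay, with a stated time of 24 h (a lower number here means a stronger inhibitor, a higher number a weaker inhibitor), and gives 9160 nM. Compound 2 `Fc1ccc(C2CC(c3ccc(Cl)cc3)=NN2c2ccc(-c3ccccc3)nn2)cc1` reaches only a limit in this assay, reported as > 100000 nM. That limit is the limit of > 100000 nM in this assay, at which 1 of the 2 values shown sits. Compound 3 `FC(F)(F)c1ccc(C2CC(c3ccc(Cl)cc3)=NN2c2ccc(-c3ccccc3)nn2)cc1` is not yet measured; it differs from compound 2 by trifluoromethyl in place of fluoro on an aromatic carbon. A step toward stronger inhibition beyond the usual scatter is expected, an at least 5.0-fold lower number from compound 2 to compound 3 (0.69 log units; beyond the scatter), because compound 1, which carries the same trifluoromethyl group, gives 9160 nM. Compound 3 is therefore estimated at 20000 nM, within 5000 nM to 100000 nM, though a limit remains possible.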

Compound 3, half-maximal inhibitory concentration: > 100000 nM
Compound 3: a limit, no number; the forecaster's own chance of this, stated with the estimate: 35%; at least 5.0-fold (0.69 log units) between middle value and limit.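

With trifluoromethyl kept, chloro in place of hydrogen on an aromatic carbon gives an at least 10-fold higher number from compound 1 to compound 3 (1.03 log units; beyond the scatter), so the trifluoromethyl group alone does not secure the activity seen in compound 1. The step from fluoro to trifluoromethyl cannot be read, because compound 2 and compound 3 each give only a limit, not a number: the limit of > 100000 nM in this assay, at which 2 of the 3 values shown sit.

Going by these compounds, whether 4-fluorophenyl to 4-(trifluoromethyl)phenyl matters in a compound without chloro stays open. So does whether an amine or a methoxy group in place of chloro would give a measurable value.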